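This account rests on a few compounds, and the source may have more. Where it says the series, first, only, none or still open, it means among the compounds named here.

Compound 1 `Cc1ccccc1NC(=O)N[C@@H](C)c1ccccc1` in an ADME assay on the whole organism with Oryza sativa as the target, tested at 1 uM (on this read-out lower numbers stand for a stronger effect and higher numbers for a weaker effect at the one concentration tested), gives 99%.
Compound 2 `Cc1cccc(NC(=O)N[C@H](C)c2ccccc2)c1` in this assay gives 98%.
Compound 3 `CCc1ccccc1NC(=O)N[C@@H](C)c1ccccc1` in this assay gives 100%.

All three values sit within the usual scatter of one another. Compound 1 and compound 2 are built from the same atoms joined differently; the difference between the two cores is not broken down here. Compound 3 differs from compound 1 by methyl in place of hydrogen on a saturated chain carbon bound to an aromatic carbon, and this change made a number 1 percentage points higher from compound 1 to compound 3 (within the scatter).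

Compound 4 `CCc1cccc(NC(=O)N[C@H](C)c2ccccc2)c1` has not yet been measured. It differs from compound 2 by methyl in place of hydrogen on a saturated chain carbon bound to an aromatic carbon, the same change at the same place. Going by the values given here, because the one measured instance gave a number 1 percentage points higher from compound 1 to compound 3 (within the scatter), the step from compound 2 to compound 4 is expected to be similar, a number 1 percentage points higher from compound 2 to compound 4 (within the scatter). Compound 4 is therefore estimated at 99%, between 94% and 100%.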

Compound 4, a percentage reported as activity, at one concentration (the size of the read-out at that concentration, not a potency): 71%
Compound 4: the middle estimate sits 28 percentage points above what was measured; the whole stated range lies above it.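

In this assay, methyl in place of hydrogen on a saturated chain carbon bound to an aromatic carbon gave a number 27 percentage points lower from compound 2 to compound 4 (beyond the scatter), so the change did not carry over unchanged from one core to the other. Set side by side, the two steps differ: the same change on two cores in this assay, a number 1 percentage points higher (within the scatter) from compound 1 to compound 3 and a number 27 percentage points lower (beyond the scatter) from compound 2 to compound 4, 28 percentage points apart, beyond the scatter of two such steps. This shows that, for these two cores, the effect of the same change depends on the core that carries it, but it does not show why, and two cores give no rule for predicting a third.

The compounds shown leave open how a longer chain such as propyl, or an amine, would behave at this place on either core. They also leave open whether the step seen on the second core would grow or fade with such groups.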